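Hydroxymethyl on the piperidine in two flavone chain series

The source may hold more compounds than are shown below. What is called first, only, known or untested is meant among the compounds shown, and "the series" means these compounds.

The measured compounds and their values in a functional assay for inhibition, read by fluorescence and spectrophotometry, with a stated time of 30 h; on this read-out lower numbers stand for stronger inhibition and higher numbers for weaker inhibition:
Compound 1 `COc1ccc(-c2cc(=O)c3ccc(OCCCCCN4CCC(C)CC4)cc3o2)cc1` gives 55100 nM.
Compound 2 `COc1ccc(-c2cc(=O)c3ccc(OCCCCCN4CCC(CCO)CC4)cc3o2)cc1` gives 49400 nM.
Compound 3 `COc1ccc(-c2cc(=O)c3ccc(OCCCCCCCN4CCC(C)CC4)cc3o2)cc1` gives 61600 nM.

In this assay compound 1 and compound 2 differ by hydroxymethyl in place of hydrogen on a saturated chain carbon bound to a saturated ring carbon, and that difference shows as a 1.1-fold lower number from compound 1 to compound 2 (0.05 log units; within the scatter). Compound 3 carries a different core: compared with compound 1 it shows (2-(4-methylpiperidin-1-yl)ethyl in place of 4-methylpiperidin-1-yl on a saturated chain carbon, five bonds along the chain from an oxygen on an aromatic ring), and the step between them is a 1.1-fold higher number from compound 1 to compound 3 (0.05 log units; within the scatter). Compound 2 and compound 3 differ in both places at once, and the step is a 1.2-fold higher number from compound 2 to compound 3 (0.10 log units; within the scatter). All three values therefore sit close together, and none of the steps between them leaves the scatter.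

Compound 4 `COc1ccc(-c2cc(=O)c3ccc(OCCCCCCCN4CCC(CCO)CC4)cc3o2)cc1` is not yet measured. Compared with compound 3 it shows (hydroxymethyl in place of hydrogen on a saturated chain carbon bound to a saturated ring carbon). This is the same change that separates compound 1 from compound 2, made on the core of compound 3 rather than that of compound 1; the place is the same in both cases. It occurs twice among the compounds here, once measured and once not.

Within the data shown here, since the first instance of this change gave a 1.1-fold lower number from compound 1 to compound 2 (0.05 log units; within the scatter), compound 4 is expected to land near compound 3, with a step of about a 1.1-fold lower number from compound 3 to compound 4 (0.04 log units; within the scatter). The estimate for compound 4 in this assay is 56000 nM, with a range from 30000 nM to 110000 nM, resting on the values of compound 1, compound 2 and compound 3 alone.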

Compound 4, half-maximal inhibitory concentration: 52700 nM
For compound 4 the middle estimate is 1.1-fold (0.03 log units) above the measured one; the measured number falls inside the stated range.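

In this assay, hydroxymethyl in place of hydrogen on a saturated chain carbon bound to a saturated ring carbon gave steps on the two cores that cannot be told apart: the same change on two cores in this assay, a 1.1-fold lower number (0.05 log units; within the scatter) from compound 1 to compound 2 and a 1.2-fold lower number (0.07 log units; within the scatter) from compound 3 to compound 4, 1.0-fold (0.02 log units) apart, within the scatter of two such steps

The new step, a 1.2-fold lower number from compound 3 to compound 4 (0.07 log units; within the scatter), is no larger than the scatter, and the same holds for a 1.1-fold higher number from compound 2 to compound 4 (0.03 log units; within the scatter), where only the chain differs, and for a 1.0-fold lower number from compound 1 to compound 4 (0.02 log units; within the scatter), where the chain and the group on the ring both differ, so the four compounds form one cluster with no order among them. This shows that the change carries from one core to the other only in a limited sense, since it leaves the number within the scatter on both; it does not show a real effect of consistent size or direction, nor that the two steps would still agree on a core where the change moved the number beyond the scatter.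

The compounds shown leave open whether any change at this end of the molecule can move the number beyond the scatter. A carboxylic acid or an amine in place of the hydroxyl, morpholine in place of the piperidine, or a much longer chain could each test this.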